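Trimming the Thiophene in a Diphenylmethyl Sulfoxide Series

The source may report more compounds than this note shows. Statements on the series, on what has been measured and on what is new or still open speak of the compounds shown alone.

In an assay on HEK293 cells for inhibition of sodium-dependent dopamine transporter (Homo sapiens), read by scintillation counting, with stated times of 5 min and 1 min (a lower number here means a stronger inhibitor, a higher number a weaker inhibitor), compound 1 `CC(C)c1nnsc1C[S+]([O-])C(c1ccccc1)c1ccccc1` gives 69100 nM, while compound 2 `[O-][S+](Cc1cc(Br)cs1)C(c1ccccc1)c1ccccc1` gives 13700 nM. Going by the values given here, compound 2 therefore holds the lowest number of the two measured so far, and the one step between them, a 5.0-fold lower number from compound 1 to compound 2 (0.70 log units; beyond the scatter), is the only guide available. Compound 3 `[O-][S+](Cc1ccsc1)C(c1ccccc1)c1ccccc1` has not yet been measured. Its difference from compound 2 is thiophen-3-yl in place of 4-bromothiophen-2-yl on a saturated chain carbon bound to a sulfur. Among the compounds with values here, no measured step covers this exact change; the single step seen swapped an entirely different ring onto the same carbon, so it speaks only loosely to a thiophene that keeps its ring but loses its bromine and moves its point of attachment. On that basis compound 3 is expected to land near compound 2, drifting if anything toward a higher number, so the estimated step is a 1.6-fold higher number from compound 2 to compound 3 (0.21 log units; within the scatter). The estimate for compound 3 in this assay is 22000 nM, with a range from 7000 nM to 70000 nM.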

Compound 3, half-maximal inhibitory concentration: 3000 nM
Compound 3: the middle estimate sits 7.3-fold (0.87 log units) above what was measured; measured number below the stated range.
By their numbers in this assay, from the lowest: compound 3; then compound 2; then compound 1.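

In this assay, the group on a saturated chain carbon bound to a sulfur still matters when the ring type stays the same: thiophen-3-yl in place of 4-bromothiophen-2-yl gives a 4.6-fold lower number from compound 2 to compound 3 (0.66 log units; beyond the scatter), although both are five-membered aromatic rings with 1 hetero atom. Measured against the 4-isopropyl-1,2,3-thiadiazol-5-yl group, the same thiophen-3-yl gives a 23-fold lower number from compound 1 to compound 3 (1.36 log units; beyond the scatter), so this one place spans a large range among the three compounds, with the thiophene lacking bromine lowest. No evidence at hand accounts for either step.

This single change both removes the bromine and moves the point of attachment, and the compounds shown cannot say which of the two carries the step. A thiophen-2-yl group without bromine would separate them, while a methyl group or an amine on the thiophen-3-yl ring would show how much further this place can be changed.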